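The source may report more compounds than this note shows. Statements on the series, on what has been measured and on what is new or still open speak of the compounds shown alone.

Compound 1 `COc1cc(-c2cc(/C=C/C(=O)c3ccc(N)cc3)[nH]n2)cc(OC)c1OC`: 6190 nM
Compound 2 `COc1cc(-c2cc(/C=C/C(=O)c3ccc(Cl)c(Cl)c3)[nH]n2)cc(OC)c1OC`: > 100000 nM
Compound 3 `COc1cc(-c2cc(/C=C/C(=O)c3ccc(F)c(F)c3)[nH]n2)cc(OC)c1OC`: 94200 nM

The three compounds share a core and were all tested in a functional assay on HCT-116 cells (Homo sapiens) for inhibition, read by sulforhodamine B assay, with a stated time of 48 h; on this read-out lower numbers stand for higher toxicity in this test and higher numbers for lower toxicity in this test. In this assay compound 1 gives 6190 nM, the lowest of the two numbers shown, so it is the most toxic of the three in this test. Compound 3 gives 94200 nM, and the step is a 15-fold higher number from compound 1 to compound 3 (1.18 log units; beyond the scatter). Compound 2 reaches only a limit of the test, > 100000 nM, that is the limit of > 100000 nM in this assay, at which 1 of the 3 values shown sits. The step is an at least 16-fold higher number from compound 1 to compound 2 (1.20 log units; beyond the scatter). Between the two halogenated compounds the change is an at least 1.0-fold lower number from compound 2 to compound 3 (0.02 log units; that floor lies within the scatter).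

Compound 4 `COc1ccc(-c2cc(/C=C/C(=O)c3ccc(N)cc3)[nH]n2)cc1OC` differs from compound 1 in another part of the molecule: hydrogen in place of methoxy on an aromatic carbon. Among the compounds with values here, none of the measured steps touches this part; all of them exchange the ring on the carbonyl carbon, so none bears directly on this change, and no measured step gives a size to expect. A modest rise in the number is estimated for compound 4, as a 2.4-fold higher number from compound 1 to compound 4 (0.38 log units; beyond the scatter). Compound 4 is thus expected to give about 15000 nM, within a range of 4000 nM to 60000 nM.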

Compound 4, concentration lethal to 50% of the cells: 7190 nM
For compound 4 the middle estimate is 2.1-fold (0.32 log units) above the measured one; the measured number falls inside the stated range.
By their numbers in this assay, from the lowest: compounds 1 and 4 (each within the scatter of the next); then compound 3. At a limit, above all of these: compound 2.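

In this assay, hydrogen in place of methoxy on this aromatic carbon, ortho to a methoxy group, gives a 1.2-fold higher number from compound 1 to compound 4 (0.07 log units; within the scatter). Within the data shown here, this is the first view of a part of the molecule other than the ring on the carbonyl carbon, and it shows that with 4-aminophenyl on that carbonyl, this methoxy group can be exchanged for hydrogen with no difference beyond the scatter. Nothing shown gives a reason for this result.

From the compounds shown here alone, it remains open what a hydroxyl, an ethoxy or a chlorine on this same carbon would give. Among these compounds, it also remains open whether hydrogen in place of methoxy would give a similar result with 3,4-difluorophenyl on the carbonyl carbon, as every comparison at this position so far carries 4-aminophenyl.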